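From a dihydroxypropyl chain to an ester on a shared core

A few compounds are considered here, and "the series" means these few. Any claim that something is new, unique, unknown or untested is made for them only; others in the source may bear on it.

Among the compounds with values here, compound 2 `Nc1nc(O)c2c(n1)n(C1OC(CO)[C@@H](O)[C@H]1O)c(=O)n2CC(O)CO` is one of three compounds measured in a functional assay (B cells) with Mus musculus as the target; on this read-out higher numbers stand for an effect only at larger amounts of compound and lower numbers for an effect already at smaller amounts. In this assay compound 2 gives 45 uM, the second highest of the three numbers. Compound 1 `C=CCn1c(=S)n(C2OC(COCc3ccccc3)[C@H]3OC(C)(C)O[C@@H]23)c2nc(N)nc(O)c21` gives 47 uM, which lies within the scatter of compound 2, so the two cannot be told apart. Compound 3 `C=CCn1c(=O)n([C@@H]2O[C@H](CO)[C@H]3OC(CCC)(CCC)O[C@H]32)c2nc(N)nc(O)c21` gives 4 uM, the lowest of the three, and its gap to compound 2 lies beyond the scatter; compound 3 differs from compound 2 in more than one place, so no single change can be read from it. Compound 4 `CCOC(=O)Cn1c(=O)n(C2OC(CO)[C@@H](O)[C@H]2O)c2nc(N)nc(O)c21` is not yet measured. It differs from compound 2 by ethoxycarbonyl in place of 1,2-dihydroxyethyl on a saturated chain carbon bound to an aromatic nitrogen. Within the data shown here, no measured pair shows a change of this kind, so compound 4 is expected to stay close to compound 2. The expected step is a 1.1-fold lower number from compound 2 to compound 4 (0.05 log units; within the scatter), not beyond the scatter. The estimate for compound 4 is 40 uM, with a range from 10 uM to 160 uM.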

Compound 4, concentration for half-maximal effect: 48 uM
Compound 4: middle estimate off by 1.2-fold (0.08 log units), on the low side; low and high end bracket the measured number.
By their numbers in this assay, from the lowest: compound 3; then compounds 2, 1 and 4 (each within the scatter of the next).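

Ethoxycarbonyl in place of 1,2-dihydroxyethyl on a saturated chain carbon bound to an aromatic nitrogen gives a 1.1-fold higher number from compound 2 to compound 4 (0.03 log units; within the scatter) in this assay. Within the data shown here, this is the only single change at this position that can be read, and it shows that this read-out does not tell the two groups apart. No measurement shown gives a reason for this result.

As far as these compounds go, it remains open whether a carboxylic acid or an amine at the end of this chain would give a step beyond the scatter. From the compounds shown here alone, it is equally open whether a longer chain at this position would do so.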